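From a Benzyl Thioether to a Fluorophenyl Ketone

The source may report more compounds than this note shows. Statements on the series, on what has been measured and on what is new or still open speak of the compounds shown alone.

Three measured compounds share one core and differ only in what sits on a saturated chain carbon bound to a sulfur. Compound 1 `C#CCSc1nnc(-c2cc(OC)c(OC)c(OC)c2)n1N1C(=O)c2ccccc2C1=O` carries an ethynyl group there, compound 2 `COc1cc(-c2nnc(SCC(=O)c3ccc(C)cc3)n2N2C(=O)c3ccccc3C2=O)cc(OC)c1OC` a (4-methylphenyl)carbonyl group, and compound 3 `COc1cc(-c2nnc(SCc3ccccc3)n2N2C(=O)c3ccccc3C2=O)cc(OC)c1OC` a phenyl group. In a functional assay on MKN-45 cells (Homo sapiens) for cytotoxicity, read by MTT assay, with a stated time of 48 h (a lower number here means a stronger inhibitor, a higher number a weaker inhibitor), compound 2 gives 9620 nM. For compound 1 this assay reports only a limit, > 200000 nM. For compound 3 the assay likewise reports only a limit, > 200000 nM, so compound 3 stands at the weak edge of what was measured, sharing that position with one other compound (the limit of > 200000 nM in this assay, at which 2 of the 3 values shown sit). The measured steps are an at least 20-fold lower number from compound 1 to compound 2 (1.31 log units; beyond the scatter), then an at least 20-fold higher number from compound 2 to compound 3 (1.31 log units; beyond the scatter), while a step that the two limits leave unreadable from compound 1 to compound 3.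

Compound 4 `COc1cc(-c2nnc(SCC(=O)c3ccc(F)cc3)n2N2C(=O)c3ccccc3C2=O)cc(OC)c1OC` has not yet been measured in this assay. It differs from compound 3 in this way: (4-fluorophenyl)carbonyl in place of phenyl on a saturated chain carbon bound to a sulfur. The closest guide is the large step from the aryl ketone of compound 2 to the phenyl of compound 3, here run in reverse with a fluorine in place of a methyl on the ring. Compound 4 is therefore expected to give about 10000 nM in this assay, with a likely range from 3000 nM to 40000 nM. That estimate implies an at least 20-fold lower number from compound 3 to compound 4 (1.30 log units; beyond the scatter), a large expected gain in potency.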

Compound 4, half-maximal inhibitory concentration: 126000 nM
Beside the measured number, compound 4's estimate is 13-fold (1.10 log units) below it; measured number outside the range, above it.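

In this assay, a carbonyl on the chain does not by itself secure activity: with that carbonyl kept, fluoro in place of methyl on an aromatic carbon gives a 13-fold higher number from compound 2 to compound 4 (1.12 log units; beyond the scatter), a large loss from one small change at the far end of the group. Nor can the (4-fluorophenyl)carbonyl group be shown to improve on the other groups at this position, on a saturated chain carbon bound to a sulfur: the steps are an at least 1.5-fold lower number from compound 3 to compound 4 (0.20 log units; that floor lies within the scatter) and an at least 1.5-fold lower number from compound 1 to compound 4 (0.20 log units; that floor lies within the scatter), and each gives only a floor within the scatter. The large gain seen with compound 2 therefore belongs to the whole (4-methylphenyl)carbonyl group rather than to every aryl ketone, and the comparison with compound 1 and compound 3 stays limited by the assay ceiling: the limit of > 200000 nM in this assay, at which 2 of the 4 values shown sit.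

The compounds shown leave open whether the methyl is unusual or the fluoro is simply a poor choice, since only these two groups appear on that aromatic carbon. A chloro, a methoxy, an ethyl or an amine there, or a plain phenyl ketone with only hydrogen in that place, would help to separate these two readings.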